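The source may report more compounds than this note shows. Statements on the series, on what has been measured and on what is new or still open speak of the compounds shown alone.

The three measured compounds share one core, differing only in the group carried on an amine nitrogen in a ring. Compound 1 `CN1CCN(c2nc(Nc3ccc(C#N)c(C(F)(F)F)c3)nc(Oc3ccnc4ccccc34)n2)CC1` carries a methyl there, and in a functional assay on DU-145 cells (Homo sapiens) for cytotoxicity, read by sulforhodamine B assay, with a stated time of 48 h (a lower number here means a stronger inhibitor of growth, a higher number a weaker inhibitor of growth), compound 1 gives 51200 nM. Compound 2 `N#Cc1ccc(Nc2nc(Oc3ccnc4ccccc34)nc(N3CCN(c4cccc(C(F)(F)F)c4)CC3)n2)cc1C(F)(F)F` carries 3-(trifluoromethyl)phenyl instead; in this assay compound 2 gives 38700 nM, so that a 1.3-fold lower number from compound 1 to compound 2 (0.12 log units; within the scatter). Compound 3 `COc1ccc(N2CCN(c3nc(Nc4ccc(C#N)c(C(F)(F)F)c4)nc(Oc4ccnc5ccccc45)n3)CC2)cc1` carries 4-methoxyphenyl. For compound 3 this assay reports only a limit, > 100000 nM, and compound 3 sits at the limit of > 100000 nM in this assay, at which 1 of the 3 values shown sits. Accordingly the step from compound 1 to compound 3 is an at least 1.9-fold higher number from compound 1 to compound 3 (0.29 log units; that floor lies within the scatter), and from compound 2 to compound 3 it is an at least 2.5-fold higher number from compound 2 to compound 3 (0.41 log units; beyond the scatter), so compound 3 stands at the weak end of what has been measured.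

Compound 4 `N#Cc1ccc(Nc2nc(Oc3ccnc4ccccc34)nc(N3CCN(c4ncccn4)CC3)n2)cc1C(F)(F)F` differs from compound 3 by pyrimidin-2-yl in place of 4-methoxyphenyl on an amine nitrogen in a ring. For the measured compounds named here, the steps that bear on this are the two that lead into compound 3, an at least 1.9-fold higher number from compound 1 to compound 3 (0.29 log units; that floor lies within the scatter) and an at least 2.5-fold higher number from compound 2 to compound 3 (0.41 log units; beyond the scatter), both modest and both only floors. Swapping one aromatic group on that nitrogen for another is therefore expected to move the number by at most a modest amount, most likely back toward the values of compounds 1 and 2. Compound 4 is estimated at 60000 nM in this assay, within 25000 nM to 150000 nM, an expected step of an at least 1.6-fold lower number from compound 3 to compound 4 (0.22 log units; that floor lies within the scatter).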

Compound 4, concentration for 50% growth inhibition: 85200 nM
Compound 4: middle estimate off by 1.4-fold (0.15 log units), on the low side; low and high end bracket the measured number.
By their numbers in this assay, from the lowest: compounds 2, 1 and 4 (each within the scatter of the next, the first and the last beyond it). At a limit, above all of these: compound 3.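

Pyrimidin-2-yl on this amine nitrogen gives a result in this assay that cannot be told apart from that of the methyl group, the step being a 1.7-fold higher number from compound 1 to compound 4 (0.22 log units; within the scatter). Against 3-(trifluoromethyl)phenyl the step is a 2.2-fold higher number from compound 2 to compound 4 (0.34 log units; beyond the scatter), the first gap beyond the scatter between two compounds in this series that both have an actual number, so the two aromatic groups at this position are not interchangeable. The value for compound 3 is a limit and not a number, so the step of an at least 1.1-fold lower number from compound 3 to compound 4 (0.06 log units; that floor lies within the scatter) is only a floor and does not separate pyrimidin-2-yl from 4-methoxyphenyl: the limit of > 100000 nM in this assay, at which 1 of the 4 values shown sits.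

The compounds shown leave open whether a longer chain, an acetyl group or a chain ending in a carboxylic acid on this nitrogen would move the number beyond the scatter from that of compound 1. They also leave open whether replacing the nitrile or the trifluoromethyl group on the shared core would change the number more than any of the swaps at this nitrogen.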